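This account rests on a few compounds, and the source may have more. Where it says the series, first, only, none or still open, it means among the compounds named here.

Of the compounds shown here, two of a shared core have been measured in a functional assay on HCT-116 cells (Homo sapiens) for cytotoxicity, read by MTT assay, with a stated time of 48 h; on this read-out higher numbers stand for weaker inhibition and lower numbers for stronger inhibition. Compound 1, with the structure `CC(C)Oc1ccc2c(Cl)ccnc2c1`, gives 2590 nM in this assay. Compound 2, with the structure `CCCCCCCCOc1ccc2c(Cl)ccnc2c1`, gives 2820 nM in this assay. These two numbers lie within the usual scatter of each other, so neither compound stands apart from the other on this read-out; the longer chain of compound 2 has made no difference that can be told from repetition noise.

Compound 3, with the structure `C=CCOc1ccc2c(Cl)ccnc2c1`, has not yet been measured. It differs from compound 1 in one place: allyl in place of isopropyl on an oxygen on an aromatic ring. The group that leaves and the group that enters are of the same size, and the allyl adds one double bond outside aromatic rings. Since compound 1 at 2590 nM and compound 2 at 2820 nM show that a change on this oxygen leaves the read-out unmoved, the expected step of a 1.0-fold higher number from compound 1 to compound 3 (0.00 log units; within the scatter) is none beyond the scatter. The estimate for compound 3 is 2600 nM, with a range from 1300 nM to 5200 nM.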

Compound 3, half-maximal inhibitory concentration: 2570 nM
Compound 3: middle estimate off by 1.0-fold (0.01 log units), on the high side; the range from low to high includes it.
By their numbers in this assay, from the lowest: compounds 3, 1 and 2 (each within the scatter of the next).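

In this assay, allyl in place of isopropyl on an oxygen on an aromatic ring gives a 1.0-fold lower number from compound 1 to compound 3 (0.00 log units; within the scatter), so adding a double bond outside aromatic rings, with the count of heavy atoms unchanged, produces no difference that can be told from repetition noise. The earlier compounds shown here carried only chains without such a double bond on this oxygen, and this step extends the flat picture at this position to an unsaturated chain. Nothing available offers an explanation for this flat result.

On these data alone, all three compounds carry only plain carbon chains on this oxygen, and it remains open whether an amine, a carboxylic acid or a phenyl ring there would move the number beyond the scatter. As far as these compounds go, it also remains open whether a change elsewhere on the shared core would do so.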